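Removing the Triazole Aryl Group Altogether

The compounds below may be only part of what the source reports. "The series", "measured", "known", "first", "only" and "open" are said of these compounds alone.

Measured so far in a functional assay on A549 cells (Homo sapiens) for antiproliferative activity, read by MTT assay, with a stated time of 72 h; a lower number here means a stronger inhibitor, a higher number a weaker inhibitor:
compound 1 `O=C1O[C@H]([C@@H](O)Cn2cc(-c3cccc(O)c3)nn2)C(OCc2ccccc2)=C1OCc1ccccc1` — 59900 nM
compound 3 `Cc1ccc(-c2cn(C[C@H](O)[C@H]3OC(=O)C(OCc4ccccc4)=C3OCc3ccccc3)nn2)cc1` — 8690 nM
compound 2 `O=C1O[C@H]([C@@H](O)Cn2cc(CCO)nn2)C(OCc2ccccc2)=C1OCc1ccccc1` gives only a limit of the assay, > 100000 nM.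

Compound 3 holds the lowest of the two numbers; compound 1 sits above it by a 6.9-fold lower number from compound 1 to compound 3 (0.84 log units; beyond the scatter), and compound 2 lies at the limit of > 100000 nM in this assay, at which 1 of the 3 values shown sits. Compound 4 `O=C1O[C@H]([C@@H](O)Cn2ccnn2)C(OCc2ccccc2)=C1OCc1ccccc1` carries hydrogen in place of 4-methylphenyl on an aromatic carbon. The step of an at least 11-fold lower number from compound 2 to compound 3 (1.06 log units; beyond the scatter) shows that an aryl group in this position matters, and the step of a 6.9-fold lower number from compound 1 to compound 3 (0.84 log units; beyond the scatter) shows the size of the aryl's substituent matters less. For compound 4 a large rise in this assay is therefore expected, a 9.2-fold higher number from compound 3 to compound 4 (0.96 log units; beyond the scatter). Compound 4 is estimated at 80000 nM, between 25000 nM and 150000 nM, with a real chance that only a limit is reported.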

Compound 4, half-maximal inhibitory concentration: > 100000 nM
Compound 4 gave a limit, no number; the forecaster's own chance of this, stated with the estimate: 45%; at least 1.2-fold (0.09 log units) between middle value and limit.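

In this assay compound 4 gives only a limit, which places hydrogen on this aromatic carbon with the 2-hydroxyethyl of compound 2 at the same limit: the limit of > 100000 nM in this assay, at which 2 of the 4 values shown sit. The loss of the 4-methylphenyl is large, an at least 11-fold higher number from compound 3 to compound 4 (1.06 log units; beyond the scatter), so the shared core with no group here does not reach the activity of compound 3. Against the 3-hydroxyphenyl there is only a floor, an at least 1.6-fold higher number from compound 1 to compound 4 (0.22 log units; that floor lies within the scatter), and the step between compound 2 and compound 4 cannot be read, since both values are limits.

Going by these compounds, whether a plain alkyl chain such as butyl can replace the aryl group remains open. So does the effect of an amine or a carboxylic acid on the phenyl ring.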